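The source may report more compounds than this note shows. Statements on the series, on what has been measured and on what is new or still open speak of the compounds shown alone.

Measured compounds:
compound 1, `CCCCSc1nnc(COc2cc(C)c3c(C)cc(=O)oc3c2)o1`: > 100000 nM
compound 2, `CCCCCCSc1nnc(COc2cc(C)c3c(C)cc(=O)oc3c2)o1`: > 100000 nM
compound 3, `CCCCCCS(=O)(=O)c1nnc(COc2cc(C)c3c(C)cc(=O)oc3c2)o1`: > 100000 nM

In a functional assay on MDA-MB-231 cells (Homo sapiens) for antiproliferative activity, read by MTT assay, with a stated time of 24 h (on this read-out lower numbers stand for stronger inhibition and higher numbers for weaker inhibition), compound 1 gives > 100000 nM, which is a limit of the assay and not a number. Compound 2 likewise gives only a limit, > 100000 nM. Compound 3 stands at the same limit, > 100000 nM. All three values sit at the limit of > 100000 nM in this assay, at which 3 of the 3 values shown sit, so compound 3 has no number of its own, only a limit shared with the other two.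

The steps among these compounds are therefore a step that the two limits leave unreadable from compound 1 to compound 2, a step that the two limits leave unreadable from compound 1 to compound 3 and a step that the two limits leave unreadable from compound 2 to compound 3. None of them can be read. Every value involved is a limit.

Compound 4, `Cc1cc(OCc2nnc(S(=O)(=O)Cc3ccccc3)o2)cc2oc(=O)cc(C)c12`, differs from compound 3 by phenyl in place of pentyl on a saturated chain carbon bound to a sulfonyl sulfur. Among the measured compounds shown here, no measured step bears readably on this change, and nothing among the three measured compounds shows any number away from the limit. The step from compound 3 to compound 4 is therefore expected to be a number no higher from compound 3 to compound 4 (the limit leaves the size open), with the most likely outcome another limit. Compound 4 is estimated at 100000 nM, within a range from 30000 nM to 300000 nM.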

Compound 4, half-maximal inhibitory concentration: 7070 nM
Estimate against measurement, compound 4: 14-fold (1.15 log units) above, and the stated range ends above it.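

In this assay, among the compounds shown here, phenyl in place of pentyl on a saturated chain carbon bound to a sulfonyl sulfur, which turns hexylsulfonyl into benzylsulfonyl, gives the first readable change: an at least 14-fold lower number from compound 3 to compound 4 (1.15 log units; beyond the scatter). Benzylsulfonyl in place of hexylsulfanyl gives an at least 14-fold lower number from compound 2 to compound 4 (1.15 log units; beyond the scatter), and benzylsulfonyl in place of butylsulfanyl gives an at least 14-fold lower number from compound 1 to compound 4 (1.15 log units; beyond the scatter). Compound 4 alone has a number, while the other three compounds stand at a value that is a limit of the assay and not a number: the limit of > 100000 nM in this assay, at which 3 of the 4 values shown sit.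

The compounds shown leave open whether the phenyl group needs the sulfonyl, which a benzylsulfanyl group would test. Also open, from the compounds shown here alone, is how a 2-phenylethyl chain on the sulfonyl sulfur, or an amine or a carboxylic acid on the phenyl group, would compare with the benzylsulfonyl group of compound 4.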